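Two Butyl Chains in Place of a Mixed Amine

A few compounds are considered here, and "the series" means these few. Any claim that something is new, unique, unknown or untested is made for them only; others in the source may bear on it.

Measured so far:
- compound 1 `CCN(CC1CC1)c1cc(C)nc2c(-c3ccc(Cl)cc3Cl)nn(C)c12`: 4.4 nM in an assay on HEK293 cells for displacement of a labelled ligand from corticotropin-releasing factor receptor 1 (Homo sapiens); a lower number here means a stronger inhibitor, a higher number a weaker inhibitor
- compound 2 `CCCN(CC1CC1)c1cc(C)nc2c(-c3ccc(Cl)cc3Cl)nn(C)c12`: 1.7 nM in this assay

Compound 2 has the lowest of the two numbers seen so far in this assay; its nearest neighbour is compound 1, and the step between them, a 2.6-fold lower number from compound 1 to compound 2 (0.41 log units; beyond the scatter), lies beyond the usual scatter.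

Compound 3 `CCCCN(CCCC)c1cc(C)nc2c(-c3ccc(Cl)cc3Cl)nn(C)c12` has not yet been measured. It differs from compound 2 in one place: dibutylamino in place of (cyclopropylmethyl)(propyl)amino on an aromatic carbon. Both chains on that nitrogen now carry four carbons, and the three-membered ring is gone.

For the measured compounds named here, only one measured step bears on this change. Going from compound 1 to compound 2 added one carbon to a chain on the same nitrogen and gave a modest improvement, a 2.6-fold lower number from compound 1 to compound 2 (0.41 log units; beyond the scatter). Compound 3 extends chains on that nitrogen further, so a number close to that of compound 2, perhaps slightly lower, is expected in this assay; the estimated step is a 1.1-fold lower number from compound 2 to compound 3 (0.05 log units; within the scatter). The estimate for compound 3 is 1.5 nM, with a range from 0.5 nM to 5 nM.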

Compound 3, inhibition constant: 0.62 nM
Compound 3: the middle estimate sits 2.4-fold (0.38 log units) above what was measured, within the range that was stated.
By their numbers in this assay, from the lowest: compound 3; then compound 2; then compound 1.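

In this assay, the three-membered ring is not needed at this position: dibutylamino, an open chain pair with no ring, gives a 2.7-fold lower number from compound 2 to compound 3 (0.44 log units; beyond the scatter). Against the shorter (cyclopropylmethyl)(ethyl)amino, the same group gives a 7.1-fold lower number from compound 1 to compound 3 (0.85 log units; beyond the scatter), so among the three compounds shown, the number falls each time the chains on this nitrogen lengthen, and none goes against that trend. No data here explain why the number falls.

The step to compound 3 makes two changes at once, since the ring leaves and the propyl chain also gives way to a butyl chain, so the compounds shown cannot say which change accounts for the lower number. Also open, going by these compounds, is how far the trend runs, and a longer chain, as in dipentylamino, or a chain carrying an ether oxygen, as in bis(2-methoxyethyl)amino, would show whether the number keeps falling or turns back up.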